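Bromo in Place of Methyl: What to Expect for Compound 3

The source may report more compounds than this note shows. Statements on the series, on what has been measured and on what is new or still open speak of the compounds shown alone.

Of the compounds shown here, two on a shared core have so far been measured in an assay on IMR-32 cells with Neuronal acetylcholine receptor; alpha4/beta2 (Homo sapiens) as the target; on this read-out lower numbers stand for smaller maximal responses and higher numbers for larger maximal responses. Compound 1 `CN1CCC[C@H]1COc1cccnc1Br` gives 7.1%. Among the measured compounds shown here, compound 2 `Cc1ccc(OC[C@@H]2CCCN2C)cn1` gives 30.9%, the higher of the two numbers; compound 1, its only neighbour in the set, lies below it by a gap that exceeds the scatter of repeated measurements. Compound 3 `CN1CCC[C@H]1COc1ccc(Br)nc1` is the next candidate for this assay; against compound 2 it carries bromo in place of methyl on an aromatic carbon. For the measured compounds named here, no step between two measured compounds matches this change, so nothing measured speaks to it directly. Going by the values given here, the only bromo-bearing compound in the set, compound 1, gives 7.1%, though its difference from compound 2 is not the same change, so that number offers only a loose hint. On that basis compound 3 is expected to fall below compound 2, a step of a number 14.9 percentage points lower from compound 2 to compound 3 (beyond the scatter). Compound 3 is estimated at 16%, with a range from 4% to 36%.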

Compound 3, largest response reached (reported as maximum), in percent of the reference or control that the assay uses: 10.6%
The estimate for compound 3 lay 5.4 percentage points above the measured number; low and high end bracket the measured number.
By their numbers in this assay, from the lowest: compounds 1 and 3 (each within the scatter of the next); then compound 2.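

At this aromatic carbon, next to the ring nitrogen and para to a group of 8 heavy atoms, the exchange of methyl for bromo can now be read directly: in this assay it gives a number 20.3 percentage points lower from compound 2 to compound 3 (beyond the scatter) and so turns the earlier loose hint into a measured step. Compound 3 at 10.6% lies within the scatter of compound 1 at 7.1% even though the bromo stands at a different place on the ring in each. Nothing measured here accounts for the step.

On these data alone, whether the step is tied to bromo itself or to the loss of methyl remains open. So does the question of whether chloro, an amine or plain hydrogen at this carbon would read closer to compound 2 or to compound 3.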